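Moving the hydroxyl round the cyclohexyl urea side chain

The compounds below may be only part of what the source reports. "The series", "measured", "known", "first", "only" and "open" are said of these compounds alone.

Compound 1 `O=C(NC1CCN(Cc2ccn(-c3ccc(C(F)(F)F)cc3)c2)CC1)N1CC[C@H](O)C1`: in an assay on HEK293 cells for displacement of a labelled ligand from melanin-concentrating hormone receptor 1 (Homo sapiens) (on this read-out higher numbers stand for weaker inhibition and lower numbers for stronger inhibition), compound 1 gives 125 nM
Compound 2 `O=C(NCC1(O)CCCCC1)NC1CCN(Cc2ccn(-c3ccc(C(F)(F)F)cc3)c2)CC1`: in this assay compound 2 gives 44 nM

Going by the values given here, compound 2 holds the lower of the two numbers measured so far; the only measured step, a 2.8-fold lower number from compound 1 to compound 2 (0.45 log units; beyond the scatter), separates it from compound 1 and exchanges the whole group on the carbonyl carbon. Compound 3 `O=C(NC[C@@H]1CCCC[C@H]1O)NC1CCN(Cc2ccn(-c3ccc(C(F)(F)F)cc3)c2)CC1` keeps the same atoms as compound 2 but joins them differently: 2-hydroxycyclohexyl in place of 1-hydroxycyclohexyl on a saturated chain carbon bound to an amide-type nitrogen. Among the compounds with values here, no measured step bears directly on shifting the hydroxyl from one ring carbon to another while the chain and the urea stay the same, so the step from compound 1 to compound 2 offers only a loose guide to how much such a side chain can move the number. The expectation for compound 3 in this assay is therefore a step of no more than the usual scatter, a 1.1-fold higher number from compound 2 to compound 3 (0.06 log units; within the scatter), in either direction. Compound 3 is estimated at 50 nM, within a range of 20 nM to 130 nM.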

Compound 3, half-maximal inhibitory concentration: 46 nM
Estimate against measurement, compound 3: 1.1-fold (0.04 log units) above; low and high end bracket the measured number.
By their numbers in this assay, from the lowest: compounds 2 and 3 (each within the scatter of the next); then compound 1.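

In this assay, putting 2-hydroxycyclohexyl in place of 1-hydroxycyclohexyl on the saturated chain carbon bound to an amide-type nitrogen gives no readable change (a 1.0-fold higher number from compound 2 to compound 3 (0.02 log units; within the scatter)), so at this position the hydroxyl can sit on either of these two ring carbons with the number staying within the scatter. The separation from the 3-hydroxypyrrolidin-1-yl urea also holds with the new side chain (a 2.7-fold lower number from compound 1 to compound 3 (0.43 log units; beyond the scatter)), and this step lies beyond the scatter. Nothing available accounts for either step.

The compounds shown leave open whether the hydroxyl is needed at all, since a plain cyclohexyl or an amine in its place would test that directly. They also leave open how 4-hydroxycyclohexyl or the other stereoisomers of 2-hydroxycyclohexyl would compare on this chain.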